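Compound 3: methoxy in place of methyl

The source may hold more compounds than are shown below. What is called first, only, known or untested is meant among the compounds shown, and "the series" means these compounds.

Of the compounds shown here, two sharing one core have been measured in an ADME assay on HPLF cells (Homo sapiens) for cytotoxicity, with a stated time of 24 h; a lower number here means that less compound is tolerated, a higher number that more compound is tolerated. Compound 1 `CN(C)c1ccc(/C=C2\CCC/C(=C\c3ccc([N+](=O)[O-])cc3)C2=O)cc1` reports > 400000 nM, which is a limit of the assay and not a number. For the measured compounds named here, compound 2 `Cc1ccc(/C=C2\CCC/C(=C\c3ccc([N+](=O)[O-])cc3)C2=O)cc1` gives 348000 nM, the only true number so far, so it cannot yet be ranked against any other measured value. The series therefore stands partly at the limit of > 400000 nM in this assay, at which 1 of the 2 values shown sits.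

The next structure is compound 3 `COc1ccc(/C=C2\CCC/C(=C\c3ccc([N+](=O)[O-])cc3)C2=O)cc1`, with methoxy in place of methyl on an aromatic carbon, para to a large group: methoxy in place of methyl on an aromatic carbon.

Going by the values given here, only one measured step bears on this change: an at least 1.1-fold lower number from compound 1 to compound 2 (0.06 log units; that floor lies within the scatter), with methyl in place of dimethylamino on an aromatic carbon. That step rests on a limit and its floor lies within the scatter, so it sets no size for a change at this place. No step beyond the scatter is expected in this assay, in either direction. The expected step is a 1.0-fold higher number from compound 2 to compound 3 (0.01 log units; within the scatter). Compound 3 is estimated at 360000 nM, with an expected range of 200000 nM to 600000 nM. A report of only a limit would not be a surprise.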

Compound 3, half-maximal cytotoxic concentration: > 400000 nM
Compound 3: a limit, no number (the forecaster's own chance of this, stated with the estimate: 35%); at least 1.1-fold (0.04 log units) between middle value and limit.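

In this assay, the change from 4-methylphenyl to 4-methoxyphenyl gives an at least 1.1-fold higher number from compound 2 to compound 3 (0.06 log units; that floor lies within the scatter), so this position now has a second step, and its floor also lies within the scatter. The step between compound 1 and compound 3 cannot be read, since both values are limits. With methoxy added, most of the values at this position are now limits, and neither step that can be read gives a size for a change at this place: the limit of > 400000 nM in this assay, at which 2 of the 3 values shown sit.

For the compounds shown here, compound 2 remains the only compound here with a true number, 348000 nM, so it is still unclear whether any group on this aromatic carbon can move the number beyond the scatter, for example a carboxylic acid, a chlorine atom or a longer alkyl chain. On these data alone, the nitro group is the same in all three compounds, so the effect of replacing it with an amine or a nitrile in this assay also remains open.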